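Extending the Acyl Group of Compound 3

This account rests on a few compounds, and the source may have more. Where it says the series, first, only, none or still open, it means among the compounds named here.

Compound 3 `CC(=O)N1CCC(NS(=O)(=O)c2ccc(NC(=O)c3ccccc3C)c3ccccc23)CC1` gives 6.7 nM in an assay on L1.2 cells for binding affinity to C-C chemokine receptor type 8 (Homo sapiens) (a higher number here means a weaker inhibitor, a lower number a stronger inhibitor), the lowest of the three numbers measured. Compound 1 `CCOC(=O)N1CCC(NS(=O)(=O)c2ccc(C(=O)NC3CCCCC3)c3ccccc23)CC1` gives 9.5 nM, which lies within the scatter of compound 3, while compound 2 `CCOC(=O)N1CCC(NS(=O)(=O)c2ccc(NCc3ccccc3)c3ccccc23)CC1` gives 45.6 nM. Going by the values given here, the only single-point step measured, a 4.8-fold higher number from compound 1 to compound 2 (0.68 log units; beyond the scatter), concerns the group on the aromatic carbon, not the carbonyl end where compound 4 `Cc1ccccc1C(=O)Nc1ccc(S(=O)(=O)NC2CCN(C(=O)CCCCN)CC2)c2ccccc12` differs from compound 3: 3-aminopropyl in place of hydrogen on a saturated chain carbon bound to a carbonyl carbon. Among the compounds with values here, no measured step touches that position, so there is no direct guide, and the change is expected to stay modest, a 1.5-fold higher number from compound 3 to compound 4 (0.17 log units; within the scatter). Compound 4 is therefore estimated at 10 nM in this assay, with a range from 3 nM to 40 nM.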

Compound 4, inhibition constant: 199 nM
Compound 4: the middle estimate sits 20-fold (1.30 log units) below what was measured; measured number above the stated range.
By their numbers in this assay, from the lowest: compounds 3 and 1 (each within the scatter of the next); then compound 2; then compound 4.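

At this position the change is far from neutral: in this assay, 3-aminopropyl in place of hydrogen on a saturated chain carbon bound to a carbonyl carbon gives a large step (a 30-fold higher number from compound 3 to compound 4 (1.47 log units; beyond the scatter)). Going by these compounds alone, this is the first measured change at this position, and it shows that the number responds strongly to what is placed there. Nothing measured here explains the size of this step.

Going by these compounds, it stays open whether the amine or the added chain accounts for the step. On these data alone, how a plain butyl chain, a shorter aminoethyl chain or a carboxylic acid at the chain end would read in this assay also remains unknown.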